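A few compounds are considered here, and "the series" means these few. Any claim that something is new, unique, unknown or untested is made for them only; others in the source may bear on it.

Measured in a functional assay on A2780cisR cells (Homo sapiens) for cytotoxicity, read by MTT assay, with a stated time of 72 h; a higher number here means a weaker inhibitor, a lower number a stronger inhibitor:
- compound 1 `CCCCNC(=O)CN(CCCCCC(=O)NO)C(=O)c1ccc(N(C)C)cc1`: 3190 nM
- compound 2 `CN(C)c1ccc(C(=O)N(CCCCCC(=O)NO)C(C)(C)C(=O)NC2CCCCC2)cc1`: 107000 nM
- compound 3 `CC(C)(C)NC(=O)C(C)(C)N(CCCCCC(=O)NO)C(=O)c1ccccc1`: 579000 nM

Compound 1 is the strongest of the three, and the gaps to compound 2 and compound 3 both lie beyond the scatter. The next compound to be read in this assay is compound 4 `CN(C)c1ccc(C(=O)N(CCCCCC(=O)NO)CC(=O)NC(C)(C)C)cc1`. It has the same atoms as compound 1, joined differently, with tert-butyl in place of butyl on an amide-type nitrogen.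

Within the data shown here, no measured pair isolates this change, so the data give no direct size for it. Compound 3 also carries tert-butyl and stands at 579000 nM, but it differs from compound 4 elsewhere too, and that value cannot be assigned to the group alone. The starting point is therefore compound 1 at 3190 nM, with a small shift towards a higher number expected, close to the edge of the scatter. The expected step is a 1.9-fold higher number from compound 1 to compound 4 (0.27 log units; within the scatter), and a wide margin is kept on the upper side. For compound 4 the estimate is 6000 nM, with an expected range of 1500 nM to 30000 nM.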

Compound 4, half-maximal inhibitory concentration: 5180 nM
Compound 4: the middle estimate sits 1.2-fold (0.06 log units) above what was measured, and the stated range covers the measured number.
By their numbers in this assay, from the lowest: compounds 1 and 4 (each within the scatter of the next); then compound 2; then compound 3.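

In this assay, tert-butyl in place of butyl on the amide-type nitrogen gives a 1.6-fold higher number from compound 1 to compound 4 (0.21 log units; within the scatter), so compound 1 and compound 4 cannot be told apart in this read-out. Among these compounds, this is the first direct reading of any single change, and it shows that rearranging the same four carbons at this place, with the core of compound 1 kept, leaves the result within the scatter of repeated measurements. No measurement shown here offers an explanation for this outcome.

From the compounds shown here alone, how a longer chain such as octyl, or a chain ending in a carboxylic acid or an amine, would read on this amide-type nitrogen remains open. The values of compound 2 at 107000 nM and compound 3 at 579000 nM also remain unassigned to any single group, as each differs from compound 1 and from compound 4 in more than one place and no pair shown separates those places.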